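Swapping a methoxyphenyl for a chlorophenyl on the shared core

The compounds below may be only part of what the source reports. "The series", "measured", "known", "first", "only" and "open" are said of these compounds alone.

Three measured compounds share a fused two-ring core. Compound 1 `Cn1c(-c2ccc(C(=O)O)cc2)nc2c(NC3CCCC3)ncnc21` carries a carboxy group on an aromatic carbon; in a functional assay on CHO cells for antagonist activity at adenosine receptor A2b (Homo sapiens), read by 33P incorporation, with a stated time of 20 min (on this read-out higher numbers stand for weaker inhibition and lower numbers for stronger inhibition), compound 1 gives only a limit of the assay, > 30000 nM. Compound 2 `COc1ccc(-c2nc3c(NC4CCCC4)ncnc3n2C)cc1` has methoxy in place of carboxy on that aromatic carbon; in this assay compound 2 likewise gives only a limit, > 30000 nM. The step from compound 1 to compound 2 is therefore a step that the two limits leave unreadable from compound 1 to compound 2, as the limit of > 30000 nM in this assay, at which 2 of the 3 values shown sit, shows. Going by the values given here, compound 3 `CCn1c(-c2ccccc2)nc2c(NC3CCOC3)ncnc21` differs from the others in several places and is the only one with a real number: in this assay compound 3 gives 11500 nM.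

Compound 2 thus stands at the limit of the assay, with no number of its own. The unmeasured compound 4 `Cn1c(-c2ccccc2Cl)nc2c(NC3CCCC3)ncnc21` differs from compound 2 by 2-chlorophenyl in place of 4-methoxyphenyl on an aromatic carbon. Among the compounds with values here, no measured step covers this change; the one step that exists is unreadable because of the limit of > 30000 nM in this assay, at which 2 of the 3 values shown sit. Within the data shown here, nothing measured points in either direction, so the expectation for compound 4 rests only on the limit of compound 2 and on the single number of compound 3. Compound 4 is expected to sit near the limit, around 20000 nM, between 5000 nM and 60000 nM. The step that this estimate means is expected to be an at least 1.5-fold lower number from compound 2 to compound 4 (0.17 log units; that floor lies within the scatter).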

Compound 4, inhibition constant: > 30000 nM
Compound 4 gave a limit, no number; the forecaster's own chance of this, stated with the estimate: 50%; at least 1.5-fold (0.17 log units) between middle value and limit.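

Compound 4 gives only a limit in this assay, > 30000 nM. Going by these compounds alone, no step from compound 2 to compound 4 can therefore be read, because both compounds rest at the same limit: the limit of > 30000 nM in this assay, at which 3 of the 4 values shown sit. The compounds shown leave open whether 2-chlorophenyl or 4-methoxyphenyl on the shared core gives the lower number.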